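Compound 3: fluoro in place of trifluoromethyl

The source may hold more compounds than are shown below. What is called first, only, known or untested is meant among the compounds shown, and "the series" means these compounds.

In a functional assay on NCI-H520 cells (Homo sapiens) (on this read-out lower numbers stand for stronger inhibition of growth and higher numbers for weaker inhibition of growth), compound 1 `O=S(=O)(/C=C/c1ccc(Cl)cc1Cl)Cc1ccc(Nc2ncnc3cc(Cl)ccc23)cc1` gives 76000 nM as a measured number, which marks weak inhibition of growth. Compound 2 `O=S(=O)(/C=C/c1ccc(C(F)(F)F)cc1F)Cc1ccc(Nc2ncnc3cc(Cl)ccc23)cc1` reads > 100000 nM as a limit of the assay and not a number. Going by these compounds, its exact place on the scale therefore stays open.

Compound 3 `O=S(=O)(/C=C/c1ccc(F)cc1F)Cc1ccc(Nc2ncnc3cc(Cl)ccc23)cc1` differs from compound 2 by fluoro in place of trifluoromethyl on an aromatic carbon, para to a large group and meta to a fluoro group (fluoro in place of trifluoromethyl on an aromatic carbon). This turns 2-fluoro-4-(trifluoromethyl)phenyl into 2,4-difluorophenyl.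

Within the data shown here, the one measured step that bears on this change, an at least 1.3-fold higher number from compound 1 to compound 2 (0.11 log units; that floor lies within the scatter), alters the same aromatic group, and its floor lies within the scatter. It gives no ground for expecting a large move in this assay, and any move is expected to be a small one toward lower numbers. The expected step, an at least 1.2-fold lower number from compound 2 to compound 3 (0.09 log units; that floor lies within the scatter), is not expected to go clearly beyond the scatter. For compound 3 the estimated value is 80000 nM, with an expected range from 35000 nM to 150000 nM and a real chance that the assay again reports only a limit.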

Compound 3, concentration for 50% growth inhibition: > 100000 nM
Compound 3: a limit, no number; the forecaster's own chance of this, stated with the estimate: 45%; middle value at least 1.2-fold (0.09 log units) from the limit.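

In this assay compound 3 gives > 100000 nM, a limit of the assay and not a number. Fluoro in place of trifluoromethyl on this aromatic carbon, para to a large group, therefore yields no readable number, and the step between compound 2 and compound 3 cannot be read, since neither compound has a number to set against the other: the limit of > 100000 nM in this assay, at which 2 of the 3 values shown sit. Against the 2,4-dichlorophenyl group, the 2,4-difluorophenyl group gives an at least 1.3-fold higher number from compound 1 to compound 3 (0.11 log units; that floor lies within the scatter), so this replacement, like the earlier one on the same aromatic group, sets no clear order, and compound 1 remains the only one of the three with a measured number.

Going by these compounds, how far compound 2 and compound 3 lie past the limit stays open, and with it whether the change from trifluoromethyl to fluoro has any effect in this assay. Also open, on these data alone, is whether an amine or a carboxylic acid on the same aromatic carbon, in place of fluoro, would give a readable number in this assay.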